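Hydroxy in Place of Trifluoromethyl: Estimating Compound 4

The compounds below may be only part of what the source reports. "The series", "measured", "known", "first", "only" and "open" are said of these compounds alone.

Compound 1, `O=C(/C=C\Nc1ccc(O)cc1)c1cn(-c2ccccc2)nc1-c1ccccc1`, gives 5000 nM in a functional assay on HT-29 cells (Homo sapiens) for antiproliferative activity, read by MTT assay, with a stated time of 48 h; a higher number here means a weaker inhibitor, a lower number a stronger inhibitor.
Compound 2, `O=C(/C=C\Nc1ccc(F)cc1)c1cn(-c2ccccc2)nc1-c1ccc(Cl)cc1`, gives only a limit of the assay in this assay, namely > 50000 nM.
Compound 3, `O=C(/C=C\Nc1ccc(C(F)(F)F)cc1)c1cn(-c2ccccc2)nc1-c1ccc(Cl)cc1`, likewise gives only a limit of the assay in this assay, namely > 50000 nM.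

Compound 3 therefore stands at the limit of this assay, without a number of its own. Among the compounds with values here, the single measured step leading to it, a step that the two limits leave unreadable from compound 2 to compound 3, cannot be read, because both of its ends sit at the limit of > 50000 nM in this assay, at which 2 of the 3 values shown sit. Compound 4, `O=C(/C=C\Nc1ccc(O)cc1)c1cn(-c2ccccc2)nc1-c1ccc(Cl)cc1`, differs from compound 3 by hydroxy in place of trifluoromethyl on an aromatic carbon. Within the data shown here, no measured step repeats this exchange, so its size has to be judged from what the single measurable compound shows: compound 1, which carries the same hydroxy group on a core lacking the chloro, gives 5000 nM in this assay. Among the measured compounds shown here, compound 4 is therefore expected to return a readable number rather than a limit, though the chloro on compound 4 has no measured counterpart with hydroxy. Compound 4 is estimated at 10000 nM, between 3000 nM and 50000 nM. The expected step of an at least 5.0-fold lower number from compound 3 to compound 4 (0.69 log units; beyond the scatter) is read against a limit and is only a lower bound on the gain.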

Compound 4, half-maximal inhibitory concentration: 2500 nM
For compound 4 the middle estimate is 4.0-fold (0.60 log units) above the measured one; the whole stated range lies above it.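

In this assay, hydroxy on this aromatic carbon, para to a large group, gives a readable number where fluoro and trifluoromethyl give none, with an at least 20-fold lower number from compound 3 to compound 4 (1.30 log units; beyond the scatter) and an at least 20-fold lower number from compound 2 to compound 4 (1.30 log units; beyond the scatter). Both of these steps start from a limit of the assay, so they give only a lower bound on the gain: the limit of > 50000 nM in this assay, at which 2 of the 4 values shown sit. With hydroxy in this place, chloro in place of hydrogen gives a 2.0-fold lower number from compound 1 to compound 4 (0.30 log units; within the scatter), so the two compounds cannot be told apart.

The compounds shown leave open whether an amine or methoxy in this place would also give a readable number. They also leave open how fluoro and trifluoromethyl compare with each other, as the step between compound 2 and compound 3 cannot be read.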